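Removing the pyridinyl arm on a trimethoxyphenyl amide

This account rests on a few compounds, and the source may have more. Where it says the series, first, only, none or still open, it means among the compounds named here.

Measured compounds:
Compound 1 `CCCCCCCCCCCCn1nnc(C(C(=O)Nc2c(OC)cc(OC)cc2OC)c2ccccn2)n1`: 590 nM
Compound 2 `CCCCCCCCCCCCn1nnc(C(C(=O)Nc2c(C(C)C)cccc2C(C)C)c2ccccn2)n1`: 26 nM
Compound 3 `CCCCCCCCCCCCn1nnc(CC(=O)Nc2c(C(C)C)cccc2C(C)C)n1`: 5 nM

Three compounds were tested in an assay on liver for inhibition of sterol O-acyltransferase 1 (Rattus norvegicus), using microsomes; a lower number here means a stronger inhibitor, a higher number a weaker inhibitor. Compound 1 stands highest; the change to compound 2 is 2,4,6-trimethoxyphenyl in place of 2,6-diisopropylphenyl on an amide-type nitrogen, and it brought a 23-fold lower number from compound 1 to compound 2 (1.36 log units; beyond the scatter). From compound 2 to compound 3 the change is hydrogen in place of pyridin-2-yl on a saturated chain carbon bound to an aromatic carbon and a carbonyl carbon, giving a 5.2-fold lower number from compound 2 to compound 3 (0.72 log units; beyond the scatter).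

Compound 4 `CCCCCCCCCCCCn1nnc(CC(=O)Nc2c(OC)cc(OC)cc2OC)n1` is not yet measured. It differs from compound 1 by hydrogen in place of pyridin-2-yl on a saturated chain carbon bound to an aromatic carbon and a carbonyl carbon, the same change seen between compound 2 and compound 3, at the same place. The two pairs differ in their cores as told by 2,4,6-trimethoxyphenyl in place of 2,6-diisopropylphenyl on an amide-type nitrogen. Resting on the step of a 5.2-fold lower number from compound 2 to compound 3 (0.72 log units; beyond the scatter), the same change on compound 1 is expected to give a 5.1-fold lower number from compound 1 to compound 4 (0.71 log units; beyond the scatter) in this assay. Compound 4 is therefore estimated at 115 nM, expected to fall between 40 nM and 350 nM.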

Compound 4, half-maximal inhibitory concentration: 24 nM
Compound 4: the middle estimate sits 4.8-fold (0.68 log units) above what was measured, and the stated range ends above it.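

Taking away the pyridin-2-yl group from compound 1 gave a 25-fold lower number from compound 1 to compound 4 (1.39 log units; beyond the scatter) in this assay, so the change lowered the number on both cores, but its size did not carry over: the same change on two cores in this assay, a 5.2-fold lower number (0.72 log units; beyond the scatter) from compound 2 to compound 3 and a 25-fold lower number (1.39 log units; beyond the scatter) from compound 1 to compound 4, 4.7-fold (0.67 log units) apart, beyond the scatter of two such steps. The step seen on one core therefore gives the direction on the other in these two pairs, but not a reliable size. Two pairs do not show which part of the cores sets the difference, or how the change would behave on any other core.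

Open, as far as these compounds go, is whether a methyl group or a fluorine atom on that saturated chain carbon would act as hydrogen does. Also open, from the compounds shown here alone, is whether a phenyl group would act as pyridin-2-yl does.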